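Trichloro core series: cytotoxicity on Vero cells, working notes

The source may hold more compounds than are shown below. What is called first, only, known or untested is meant among the compounds shown, and "the series" means these compounds.

Measured so far:
compound 1, `CC(C)C(=O)c1c(Nc2ccc(F)c(F)c2F)[nH]c2c(F)cc(F)cc2c1=O`: > 25000 nM
compound 2, `CC(C)C(=O)c1c(Nc2ccc(F)cc2F)[nH]c2c(F)cc(F)cc2c1=O`: > 25000 nM
compound 3, `CC(C)C(=O)c1c(Nc2ccc(F)c(F)c2F)[nH]c2c(Cl)cc(Cl)c(Cl)c2c1=O`: 6400 nM

In an ADME assay on Vero cells (Chlorocebus sabaeus) for cytotoxicity (on this read-out lower numbers stand for higher toxicity in this test and higher numbers for lower toxicity in this test), compound 1 gives > 25000 nM, which is a limit of the assay and not a number. Compound 2 gives > 25000 nM in this assay, likewise a limit. The change from compound 1 to compound 2 is hydrogen in place of fluoro on an aromatic carbon; its step that the two limits leave unreadable from compound 1 to compound 2 cannot be sized because both values sit at the limit of > 25000 nM in this assay, at which 2 of the 3 values shown sit.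

Among the compounds with values here, compound 3 gives 6400 nM in this assay, the only number so far. The difference between the core of compound 3 and the core of compound 1 is not broken down here.

Compound 4 `CC(C)C(=O)c1c(Nc2ccc(F)cc2F)[nH]c2c(Cl)cc(Cl)c(Cl)c2c1=O` is not yet measured. It differs from compound 3 by hydrogen in place of fluoro on an aromatic carbon, the same change as from compound 1 to compound 2, at the same place. Within the data shown here, the only measured instance of this change is unreadable, so a small step is expected: compound 4 is estimated at 7000 nM, between 3500 nM and 15000 nM. The expected step of a 1.1-fold higher number from compound 3 to compound 4 (0.04 log units; within the scatter) rests on the unreadable a step that the two limits leave unreadable from compound 1 to compound 2 and on the scatter of this assay, with some chance that only a limit is returned.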

Compound 4, half-maximal cytotoxic concentration: > 25000 nM
Compound 4 ended at the assay's limit; the forecaster's own chance of this, stated with the estimate: 15%; at least 3.5-fold (0.55 log units) between middle value and limit.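

In this assay, going from 2,3,4-trifluorophenyl to 2,4-difluorophenyl on the core of compound 3 gives an at least 3.9-fold higher number from compound 3 to compound 4 (0.59 log units; beyond the scatter). Compound 4 gives > 25000 nM, which is a limit of the assay and not a number. This shows that the change can matter on this core, but whether the step carries over to the core of compound 1 cannot be read, because the pair there gives no number: the limit of > 25000 nM in this assay, at which 3 of the 4 values shown sit.

Still open, on these data alone, is how the core of compound 3 behaves with an amine or a carboxylic acid at the place where the fluoro leaves. Also open, as far as these compounds go, is whether either core with the 2,4-difluorophenyl group can give a readable number.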